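Working notes: cytotoxicity, compound 2 to compound 4

The source may report more compounds than this note shows. Statements on the series, on what has been measured and on what is new or still open speak of the compounds shown alone.

Compound 1 `O/N=C(\c1nnc(C(F)(F)F)s1)c1nc2ccccc2s1`: in an ADME assay on CHO cells (Cricetulus griseus) for cytotoxicity (a higher number here means a weaker inhibitor, a lower number a stronger inhibitor), compound 1 gives 15600 nM.
Compound 2 `Cc1cnc(/C(=N\O)c2nc3ccccc3s2)s1`: in this assay compound 2 gives 29000 nM.
Compound 3 `CON=C(c1nc2ccccc2s1)c1nc2ccccc2s1`: in this assay compound 3 reaches only a limit, > 50000 nM.

Compound 2 has the higher of the two numbers in this assay, with compound 1 nearest, a gap that sits within the scatter. The third value is a limit, (the limit of > 50000 nM in this assay, at which 1 of the 3 values shown sits).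

Compound 4 `O/N=C(/c1nc2ccccc2s1)C1CCCCC1` is not yet measured. It differs from compound 2 by cyclohexyl in place of 5-methyl-1,3-thiazol-2-yl on a carbon with a double bond to nitrogen. Going by the values given here, no measured pair shows this kind of change, so no step size can be read off. The expectation for compound 4 in this assay is a step of a 1.0-fold higher number from compound 2 to compound 4 (0.01 log units; within the scatter), that is, nothing clearly beyond the scatter. Compound 4 is estimated at 30000 nM, between 12000 nM and 80000 nM.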

Compound 4, half-maximal inhibitory concentration: 51600 nM
Compound 4: middle estimate off by 1.7-fold (0.24 log units), on the low side; low and high end bracket the measured number.
By their numbers in this assay, from the lowest: compounds 1, 2 and 4 (each within the scatter of the next, the first and the last beyond it).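

In this assay, cyclohexyl takes the place of 5-methyl-1,3-thiazol-2-yl on a carbon with a double bond to nitrogen with no shift beyond the scatter (a 1.8-fold higher number from compound 2 to compound 4 (0.25 log units; within the scatter)). This first step at the position shows that a ring of carbon only, with no hydrogen-bond acceptors, reads within the scatter of the five-membered aromatic ring. Compound 3 stands at a limit, not a number: the limit of > 50000 nM in this assay, at which 1 of the 4 values shown sits.

Still open, as far as these compounds go, is how an amine, a carboxylic acid or a longer chain on this carbon would read in this assay.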